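The source may report more compounds than this note shows. Statements on the series, on what has been measured and on what is new or still open speak of the compounds shown alone.

Values in a functional assay on A549 cells (Homo sapiens) for inhibition; a higher number here means a weaker inhibitor, a lower number a stronger inhibitor:
- compound 1 `CCN(CC)CCNC(=O)CC(CC(=O)NC1Cc2ccccc2C1)c1ccc(Cl)cc1`: 48600 nM
- compound 2 `CCN(CC)CCNC(=O)CC(CC(=O)NC1Cc2ccccc2C1)c1ccccc1`: 82400 nM

Compound 1 has the lower of these two numbers, but the pair stands within the scatter. Compound 3 `CCN(CC)CCNC(=O)CC(CC(=O)N(C)C1Cc2ccccc2C1)c1ccc(Cl)cc1` is unmeasured and carries one change from compound 1: methyl in place of hydrogen on an amide-type nitrogen. Going by the values given here, the only measured step, a 1.7-fold higher number from compound 1 to compound 2 (0.23 log units; within the scatter), lies at an aromatic carbon, so it bears only indirectly and no measured step covers this nitrogen. No step beyond the scatter is therefore expected in this assay, and no direction can be assigned. The estimated step is a 1.1-fold higher number from compound 1 to compound 3 (0.05 log units; within the scatter). For compound 3 the expected value is 55000 nM, with an estimated range of 20000 nM to 150000 nM.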

Compound 3, half-maximal inhibitory concentration: 21400 nM
Estimate against measurement, compound 3: 2.6-fold (0.41 log units) above; the range from low to high includes it.
By their numbers in this assay, from the lowest: compound 3; then compounds 1 and 2 (each within the scatter of the next).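

Methyl in place of hydrogen on this amide-type nitrogen gives, in this assay, a 2.3-fold lower number from compound 1 to compound 3 (0.36 log units; beyond the scatter). Going by these compounds alone, this nitrogen therefore responds to substitution, and the step is the first to pass the scatter, whereas a 1.7-fold higher number from compound 1 to compound 2 (0.23 log units; within the scatter) at the aromatic carbon does not. No available evidence accounts for the step.

Open, on these data alone, is whether ethyl or a longer chain on this nitrogen moves the number further, or reverses it. Also open, as far as these compounds go, is whether methyl has the same effect on the core of compound 2, which lacks the chloro.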